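Replacing the piperidine amide of compound 1 with a toluoyl amide

This account rests on a few compounds, and the source may have more. Where it says the series, first, only, none or still open, it means among the compounds named here.

Measured so far:
- compound 1, `COc1ccc(-c2cnc(NC(=O)C3CCNCC3)n2C)cc1`: > 100000 nM
- compound 2, `O=C(Nc1ncc(-c2ccccc2)o1)c1ccc(Cl)cc1`: 10000 nM
- compound 3, `Cn1c(-c2ccc(C#N)cc2)cnc1NC(=O)c1ccc(F)cc1`: > 50000 nM

In a toxicity assay on THP-1 cells (Homo sapiens) for inhibition (a higher number here means that more compound is tolerated, a lower number that less compound is tolerated), compound 1 reaches only a limit, > 100000 nM, and no number. This is the limit described by the limit of > 100000 nM in this assay, at which 1 of the 3 values shown sits. Compound 3 likewise gives only a limit, > 50000 nM, as noted in the limit of > 50000 nM in this assay, at which 1 of the 3 values shown sits. Going by the values given here, compound 2 is the one compound with a number, 10000 nM. Among the compounds with values here, compound 1 therefore stands among the compounds for which this assay reports no value at all, and no step between measured compounds is available to calibrate the change about to be made.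

Compound 4, `COc1ccc(-c2cnc(NC(=O)c3ccccc3C)n2C)cc1`, differs from compound 1 by 2-methylphenyl in place of piperidin-4-yl on a carbonyl carbon. Compound 3 carries an aromatic amide on the same core and gives only a limit, while compound 2, with an aromatic amide on a different core, gives a number, so the expected step of an at least 2.5-fold lower number from compound 1 to compound 4 (0.39 log units; beyond the scatter) is towards a lower tolerated concentration, moderate in size. Compound 4 is estimated at 40000 nM, within 10000 nM to 150000 nM.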

Compound 4, half-maximal cytotoxic concentration: > 100000 nM
Compound 4 ended at the assay's limit; the forecaster's own chance of this, stated with the estimate: 40%; at least 2.5-fold (0.39 log units) between middle value and limit.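

In this assay, compound 1 and compound 4 both end at a limit of the assay rather than at a number, so the step between them cannot be read. On these data alone, whether 2-methylphenyl in place of piperidin-4-yl changes the tolerated concentration at all stays open.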